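Chloro compound 3 and its unmeasured partner, compound 4

This account rests on a few compounds, and the source may have more. Where it says the series, first, only, none or still open, it means among the compounds named here.

Values in a functional assay (Homo sapiens) for inhibition; on this read-out higher numbers stand for weaker inhibition and lower numbers for stronger inhibition:
- compound 1 `CSc1ccc(CSc2nc(-c3ccc(F)cc3)c(-c3ccncc3)[nH]2)cc1`: 670 nM
- compound 2 `C[S+]([O-])c1ccc(CCSc2nc(-c3ccc(F)cc3)c(-c3ccncc3)[nH]2)cc1`: 500 nM
- compound 3 `CSc1ccc(CSc2nc(-c3ccc(Cl)cc3)c(-c3ccncc3)[nH]2)cc1`: 2200 nM

Compound 3 has the highest number of the three in this assay. Compound 4 `C[S+]([O-])c1ccc(CSc2nc(-c3ccc(Cl)cc3)c(-c3ccncc3)[nH]2)cc1` differs from it on an aromatic carbon, para to a large group: a group of 3 heavy atoms (1 carbon, 1 oxygen, 1 sulfur; no ring) in place of a group of 2 heavy atoms (1 carbon, 1 sulfur; no ring), on an aromatic carbon. The closest evidence is a 1.3-fold lower number from compound 1 to compound 2 (0.13 log units; within the scatter), though that step changes more than this one group. The chloro level is set by a 3.3-fold higher number from compound 1 to compound 3 (0.52 log units; beyond the scatter), and compound 4 keeps the chloro. The expected change is a 1.3-fold lower number from compound 3 to compound 4 (0.11 log units; within the scatter), with no shift beyond the scatter anticipated. For compound 4 the estimated value is 1700 nM, with an expected range of 750 nM to 3800 nM.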

Compound 4, half-maximal inhibitory concentration: 320 nM
Compound 4: the middle estimate sits 5.3-fold (0.73 log units) above what was measured; the measured number lies below the stated range.
By their numbers in this assay, from the lowest: compounds 4, 2 and 1 (each within the scatter of the next, the first and the last beyond it); then compound 3.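

In this assay, replacing methylsulfanyl with the group of 3 heavy atoms on an aromatic carbon, para to a large group, with the chloro kept, gives a 6.9-fold lower number from compound 3 to compound 4 (0.84 log units; beyond the scatter). This single change therefore moves the number beyond the scatter, which the earlier 1.3-fold lower number from compound 1 to compound 2 (0.13 log units; within the scatter) did not show, as that step also changes more than this one group. Nothing available bears on the reason for this step.

From the compounds shown here alone, whether the same swap gives a step of this size with fluoro in place of chloro remains open, as compound 1 and compound 2 differ in more than this group. Going by these compounds, how an amine or a carboxylic acid would read out on this aromatic carbon also remains open.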